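Anilino-substituted analogues in the cell growth series

The compounds below may be only part of what the source reports. "The series", "measured", "known", "first", "only" and "open" are said of these compounds alone.

Measured so far:
compound 1, `Cc1nc(SCC(=O)Nc2nc(-c3ccc(Cl)cc3)cs2)n(Nc2ccccc2)c1C`, in a functional assay on NCI-H322M cells (Homo sapiens) for antiproliferative activity, read by sulforhodamine B assay, with a stated time of 48 h; a lower number here means a stronger inhibitor of growth, a higher number a weaker inhibitor of growth: 22900 nM
compound 2, `Cc1ccc(Nn2c(SCC(=O)Nc3nc(-c4ccccc4)cs3)nc(C)c2C)cc1`, in this assay: > 100000 nM

Going by the values given here, compound 1 gives the only numerical value in this assay so far. Compound 2 sits at a limit of this assay, not at a number, which is the limit of > 100000 nM in this assay, at which 1 of the 2 values shown sits. Among the compounds with values here, no single-change step between measured compounds exists, so the two values show only that compound 1 is measurable while compound 2 is not.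

Compound 3 is `COc1ccc(Nn2c(SCC(=O)Nc3nc(-c4ccc(Cl)cc4)cs3)nc(C)c2C)cc1`. It differs from compound 1 by methoxy in place of hydrogen on an aromatic carbon, a methoxy in place of hydrogen on an aromatic carbon, para to a large group, so the phenyl becomes 4-methoxyphenyl and the anilino becomes (4-methoxyphenyl)amino. Within the data shown here, no measured step guides this change. For compound 3 the step is expected to be modest and toward weaker growth inhibition, a 2.0-fold higher number from compound 1 to compound 3 (0.29 log units; within the scatter), with a real chance of a limit only. Compound 3 is estimated at 45000 nM, in the range 12000 nM to 150000 nM.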

Compound 3, concentration for total growth inhibition: > 100000 nM
Compound 3 was reported as a limit; the forecaster's own chance of this, stated with the estimate: 35%; at least 2.2-fold (0.34 log units) between middle value and limit.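

Methoxy in place of hydrogen on an aromatic carbon, para to a large group, gives the first single-change step in this series, and in this assay it reads as an at least 4.3-fold higher number from compound 1 to compound 3 (0.64 log units; beyond the scatter). Compound 3 gives > 100000 nM, which is a limit of the assay and not a number. The step therefore fixes only a lower bound on the size of the change, though that bound already lies beyond the scatter, and the limit now holds most of the series: the limit of > 100000 nM in this assay, at which 2 of the 3 values shown sit.

As far as these compounds go, whether fluorine, a hydroxyl or a dimethylamino group on this aromatic carbon would keep growth inhibition measurable remains open. Going by these compounds alone, with only one numerical value in this assay, the full size of the methoxy step also stays open.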